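This account rests on a few compounds, and the source may have more. Where it says the series, first, only, none or still open, it means among the compounds named here.

Working notes on the series in a functional assay on MCF7 cells (Homo sapiens) for inhibition, read by MTT assay, with a stated time of 24 h; a lower number here means a stronger inhibitor, a higher number a weaker inhibitor.

Compound 1 `Cc1ccccc1OCc1nnc(S)n1N1C(=O)CSC1c1c[nH]nc1-c1ccc(Cl)cc1` gives 22 ug/mL in this assay. Compound 2 `COc1ccc(-c2n[nH]cc2C2SCC(=O)N2n2c(S)nnc2COc2ccccc2C)cc1` gives 29 ug/mL; among the two measured numbers compound 2 holds the higher one, but the step of a 1.3-fold higher number from compound 1 to compound 2 (0.12 log units; within the scatter) does not carry the pair apart. That step is the only measured one, and it concerns methoxy in place of chloro on an aromatic carbon, not the ether-linked ring.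

Compound 3 `COc1ccc(-c2n[nH]cc2C2SCC(=O)N2n2c(S)nnc2COc2ccc(C)cc2)cc1` is not yet measured. It differs from compound 2 as follows: 4-methylphenyl in place of 2-methylphenyl on an oxygen on a saturated carbon. For the measured compounds named here, no measured step touches the 2-methylphenyl to 4-methylphenyl exchange, so nothing in the data speaks for a step beyond the scatter in either direction.

The estimate for compound 3 in this assay is therefore 29 ug/mL, expected to fall between 14 ug/mL and 60 ug/mL. That corresponds to an expected step of no change at the digits printed from compound 2 to compound 3 (within the scatter), essentially flat.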

Compound 3, half-maximal inhibitory concentration: 78 ug/mL
Compound 3: the middle estimate sits 2.7-fold (0.43 log units) below what was measured, and the stated range ends below it.
By their numbers in this assay, from the lowest: compounds 1 and 2 (each within the scatter of the next); then compound 3.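

In this assay, for the compounds shown here, the exchange of 2-methylphenyl for 4-methylphenyl on an oxygen on a saturated carbon gives a 2.7-fold higher number from compound 2 to compound 3 (0.43 log units; beyond the scatter) and is the only step in this short series that lies beyond the scatter. The two groups have the same atoms and the same counts, so this position responds to where the methyl group sits on the ring and not only to which atoms are present, with the 4-methylphenyl compound the weaker of the pair. No measurement available here accounts for the step.

Going by these compounds, whether the exchange gives a similar step with chloro in place of methoxy on the aromatic carbon remains open. Also open, on these data alone, is how this position responds to an unsubstituted phenyl, or to a ring carrying an amine or a carboxylic acid.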